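From Isopropyl to Pyridin-2-yl: Estimating Compound 3

This account rests on a few compounds, and the source may have more. Where it says the series, first, only, none or still open, it means among the compounds named here.

Measured so far:
- compound 1, `CCCC(c1ccccc1)n1ccc2cc(/C(C)=C/C(=O)Nc3ccccc3OCCCC(=O)O)ccc21`, gives 9.1 nM in an assay on Prostate gland for inhibition of steroid 5-alpha-reductase (Rattus norvegicus); a lower number here means a stronger inhibitor, a higher number a weaker inhibitor
- compound 2, `C/C(=C\C(=O)Nc1ccccc1OCCCC(=O)O)c1ccc2c(ccn2C(c2ccccc2)C(C)C)c1`, gives 25 nM in this assay

Compound 2 holds the higher of the two numbers, meaning the weaker inhibition. Among the measured compounds shown here, its only neighbour is compound 1, and the step between them, a 2.7-fold higher number from compound 1 to compound 2 (0.44 log units; beyond the scatter), came from a single substitution: isopropyl in place of propyl on a saturated chain carbon bound to an aromatic carbon and an aromatic nitrogen. So the group on this carbon does move the number, though only modestly.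

Compound 3, `C/C(=C\C(=O)Nc1ccccc1OCCCC(=O)O)c1ccc2c(ccn2C(c2ccccc2)c2ccccn2)c1`, has not yet been measured. It differs from compound 2 by pyridin-2-yl in place of isopropyl on a saturated chain carbon bound to an aromatic carbon and an aromatic nitrogen. For the measured compounds named here, the one measured step that bears on this position, from compound 1 to compound 2, is the only guide, and it says nothing about whether an aromatic ring here behaves more like propyl or like isopropyl. A modest shift in either direction is plausible, and the expectation is centred close to compound 2.

Compound 3 is therefore estimated at 20 nM, with a range from 6 nM to 70 nM. That estimate means an expected step of a 1.3-fold lower number from compound 2 to compound 3 (0.10 log units; within the scatter).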

Compound 3, half-maximal inhibitory concentration: 37 nM
Beside the measured number, compound 3's estimate is 1.9-fold (0.27 log units) below it, and the stated range covers the measured number.
By their numbers in this assay, from the lowest: compound 1; then compounds 2 and 3 (each within the scatter of the next).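

In this assay, pyridin-2-yl is tolerated on the saturated chain carbon bound to an aromatic carbon and an aromatic nitrogen: a larger group with a ring and a hydrogen-bond acceptor leaves compound 3 level with compound 2, with a 1.5-fold higher number from compound 2 to compound 3 (0.17 log units; within the scatter). Measured against propyl, the same ring gives a clearer difference, a 4.1-fold higher number from compound 1 to compound 3 (0.61 log units; beyond the scatter), so among these three compounds, both replacements of propyl give a number beyond the scatter of compound 1, which remains the strongest inhibitor shown. Nothing available here gives a reason for these differences.

From the compounds shown here alone, it remains open whether the ring nitrogen of pyridin-2-yl plays any part in the number for compound 3, a question that a phenyl group or a pyridin-3-yl group on this carbon would help to answer. Going by these compounds, it is also open whether a shorter chain such as ethyl or a longer one such as butyl on this carbon would give a lower number than propyl does in compound 1.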